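Removing the ring nitrogen substituent: compound 3 to compound 4

The source may hold more compounds than are shown below. What is called first, only, known or untested is meant among the compounds shown, and "the series" means these compounds.

The shared core is kept throughout; the series varies only the group on the amide-type nitrogen in the ring. Compound 1 `CC(C)N1C(=O)COc2ccc(-c3cccc(NS(=O)(=O)c4ccc(F)cc4)c3)cc21` carries isopropyl there, compound 2 `O=C1COc2ccc(-c3cccc(NS(=O)(=O)c4ccc(F)cc4)c3)cc2N1c1ccc(F)cc1` a 4-fluorophenyl, compound 3 `O=C1COc2ccc(-c3cccc(NS(=O)(=O)c4ccc(F)cc4)c3)cc2N1C1CCCCC1` a cyclohexyl. In a functional assay on MCF7 cells (Homo sapiens) for antiproliferative activity, read by MTT assay, with a stated time of 72 h (a higher number here means a weaker inhibitor, a lower number a stronger inhibitor), compound 1 gives 26000 nM. In this assay compound 2 gives only a limit, > 40000 nM. In this assay compound 3 gives 21400 nM. The measured steps are all small: a 1.2-fold lower number from compound 1 to compound 3 (0.08 log units; within the scatter), an at least 1.5-fold higher number from compound 1 to compound 2 (0.18 log units; that floor lies within the scatter), an at least 1.8-fold lower number from compound 2 to compound 3 (0.27 log units; that floor lies within the scatter), the latter two resting on the limit (the limit of > 40000 nM in this assay, at which 1 of the 3 values shown sits). Compound 3 thus holds the lowest of the two numbers, with compound 1 close by within the scatter and the third value a limit.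

Compound 4 `O=C1COc2ccc(-c3cccc(NS(=O)(=O)c4ccc(F)cc4)c3)cc2N1` strips the ring nitrogen bare: hydrogen in place of cyclohexyl on an amide-type nitrogen in a ring. Going by the values given here, the steps that bear on it are the exchanges at the same nitrogen, from compound 1 to compound 3 and from compound 1 to compound 2, and none of them moved beyond the scatter, so no movement beyond the scatter is expected in this assay for this change either, in either direction. The expected step is a 1.0-fold higher number from compound 3 to compound 4 (0.01 log units; within the scatter). Compound 4 is estimated at 22000 nM in this assay, within 8000 nM to 60000 nM.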

Compound 4, half-maximal inhibitory concentration: 18300 nM
Compound 4: the middle estimate sits 1.2-fold (0.08 log units) above what was measured; the measured number falls inside the stated range.
By their numbers in this assay, from the lowest: compounds 4, 3 and 1 (each within the scatter of the next). At a limit, above all of these: compound 2.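

Stripping the amide-type nitrogen in a ring to hydrogen removes the carbon substituent altogether, yet in this assay the number stays within the scatter of both alkyl-bearing compounds: the loss of cyclohexyl gives a 1.2-fold lower number from compound 3 to compound 4 (0.07 log units; within the scatter), and the loss of isopropyl gives a 1.4-fold lower number from compound 1 to compound 4 (0.15 log units; within the scatter). Among the compounds shown, neither of these two groups therefore separates from hydrogen at this position, and the exchange of 4-fluorophenyl for hydrogen is the only one here that clears the scatter, with an at least 2.1-fold lower number from compound 2 to compound 4 (0.33 log units; beyond the scatter). That step is a floor and not a measured size, since compound 2 gives a limit and not a number: the limit of > 40000 nM in this assay, at which 1 of the 4 values shown sits.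

Still open, as far as these compounds go, is whether any group on this nitrogen can lower the number beyond the scatter relative to hydrogen, for instance a longer chain ending in an amine or a carboxylic acid. Also open, from the compounds shown here alone, is whether the step from 4-fluorophenyl belongs to the fluorine or to the aromatic ring itself, which an unsubstituted phenyl or a benzyl group at the same nitrogen would help to separate.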